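The source may hold more compounds than are shown below. What is called first, only, known or untested is meant among the compounds shown, and "the series" means these compounds.

The measured compounds and their numbers in a functional assay on HeLa cells for antagonist activity at 5-hydroxytryptamine receptor 6 (Homo sapiens), read by cAMP accumulation and immunoassay; on this read-out lower numbers stand for stronger inhibition and higher numbers for weaker inhibition:

compound 1, `CN1CCC(n2cc(S(=O)(=O)c3ccccc3F)c3cccnc32)C1`, 186 nM
compound 2, `CN1CCC(n2cc(S(=O)(=O)c3ccc(F)cc3)c3cccnc32)C1`, 213 nM
compound 3, `CN1CCC(n2cc(S(=O)(=O)c3cccc(Cl)c3)c3cccnc32)C1`, 142 nM

Compound 1 holds the second highest number of the three, though all three sit within the usual scatter of one another: its nearest neighbour is compound 2, a 1.1-fold higher number from compound 1 to compound 2 (0.06 log units; within the scatter), and the furthest is compound 3, a 1.3-fold lower number from compound 1 to compound 3 (0.12 log units; within the scatter). Compound 4, `CN1CCC(n2cc(S(=O)(=O)c3ccc(Cl)cc3)c3cccnc32)C1`, has not yet been measured in this assay. It differs from compound 1 in one place: 4-chlorophenyl in place of 2-fluorophenyl on a sulfonyl sulfur. For the measured compounds named here, two measured steps bear on this change. Moving the fluorine from the 2-fluorophenyl to the 4-fluorophenyl gave a 1.1-fold higher number from compound 1 to compound 2 (0.06 log units; within the scatter), and exchanging the 2-fluorophenyl for a 3-chlorophenyl gave a 1.3-fold lower number from compound 1 to compound 3 (0.12 log units; within the scatter); the step between these two, a 1.5-fold lower number from compound 2 to compound 3 (0.18 log units; within the scatter), was likewise small. Nothing in these three compounds suggests that a 4-chlorophenyl would move this assay beyond the scatter, so a step of essentially no size is expected, a 1.1-fold lower number from compound 1 to compound 4 (0.04 log units; within the scatter). Compound 4 is therefore estimated to give 170 nM, with a range from 80 nM to 360 nM.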

Compound 4, half-maximal inhibitory concentration: 95 nM
Beside the measured number, compound 4's estimate is 1.8-fold (0.25 log units) above it; the range from low to high includes it.
By their numbers in this assay, from the lowest: compounds 4, 3, 1 and 2 (each within the scatter of the next, the first and the last beyond it).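

In this assay, for the compounds shown here, exchanging fluoro for chloro on an aromatic carbon gives the only new step that lies beyond the scatter, a modest one (a 2.2-fold lower number from compound 2 to compound 4 (0.35 log units; beyond the scatter)). The other two new steps stay within the scatter (a 2.0-fold lower number from compound 1 to compound 4 (0.29 log units; within the scatter) and a 1.5-fold lower number from compound 3 to compound 4 (0.17 log units; within the scatter)), so compound 4 cannot be separated from compound 1 or compound 3, and the change of halogen on the group at the sulfonyl sulfur has a readable effect only in the pair of compound 2 and compound 4. No measurement offered here explains that step.

All four compounds carry a single halogen on the phenyl group at the sulfonyl sulfur. On these data alone, it remains open how a methoxy group, a nitrile or a bromine there would fare in this assay, or whether a second chlorine would lower the number further.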